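The compounds below may be only part of what the source reports. "The series", "measured", "known", "first", "only" and "open" are said of these compounds alone.

Measured so far in an ADME assay on microsomes from liver (Rattus norvegicus) for metabolic stability, with a stated time of 10 min, tested at 0.5 uM; on this read-out lower numbers stand for a less stable compound and higher numbers for a more stable compound 
- compound 1 `Cc1noc(C)c1[C@@H]1C[C@@](C)(c2ccc(F)cc2F)N=C(N)S1` gives 78% 
- compound 2 `Cc1nocc1[C@@H]1C[C@@](C)(c2ccc(F)cc2F)N=C(N)S1` gives 77% 

Compound 2 at 77% lies within the scatter of compound 1, so the two cannot be told apart on this read-out. The next structure is compound 3 `Cn1nccc1[C@@H]1C[C@@](C)(c2ccc(F)cc2F)N=C(N)S1`, which carries 1-methyl-1H-pyrazol-5-yl in place of 3-methyl-1,2-oxazol-4-yl on a saturated ring carbon on a saturated ring carbon next to the ring sulfur. Among the measured compounds shown here, the one measured step of a number 1 percentage points lower from compound 1 to compound 2 (within the scatter) is small, but it only puts hydrogen in place of methyl on an aromatic carbon and leaves the aromatic ring itself unchanged. For the measured compounds named here, the data therefore hold no direct precedent for exchanging that ring, and the margins must stay wide. The expected step is a number 4 percentage points lower from compound 2 to compound 3 (within the scatter) in this assay and is not expected to go beyond the scatter. For compound 3 the estimated value is 73% with 55% as the lower end and 88% as the upper end.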

Compound 3, percent of the compound remaining: 78%
Estimate against measurement, compound 3: 5 percentage points below; the measured number falls inside the stated range.
By their numbers in this assay, from the lowest: compounds 2, 1 and 3 (each within the scatter of the next).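

Notes on the saturated ring carbon next to the ring sulfur: the earlier step changed only a methyl on the aromatic ring, whereas these steps exchange the ring itself. In this assay, 1-methyl-1H-pyrazol-5-yl in place of 3-methyl-1,2-oxazol-4-yl gives (a number 1 percentage points higher from compound 2 to compound 3 (within the scatter)), and in place of 3,5-dimethyl-1,2-oxazol-4-yl it gives (no change at the digits printed from compound 1 to compound 3 (within the scatter)), so this read-out does not separate the two ring types among compounds 1, 2 and 3. No supporting information is available to explain this result.

Going by these compounds, all three groups at this carbon are five-membered aromatic rings with 2 hetero atoms, so a phenyl ring, a pyridyl ring, an amine or a carboxylic acid there remains open. The group of 8 heavy atoms is also the same throughout, leaving open how a change there would read.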